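The compounds below may be only part of what the source reports. "The series", "measured", "known", "first", "only" and "open" are said of these compounds alone.

Measured in a functional assay on A549 cells (Homo sapiens) for cytotoxicity, read by MTT assay, with a stated time of 72 h; on this read-out higher numbers stand for weaker inhibition and lower numbers for stronger inhibition:
- compound 1 `COc1ccc(/C=C/C(=O)Nc2cc3c(Nc4ccc(F)c(Cl)c4)ncnc3cc2OC)cc1`: "not active" (no number reported)
- compound 2 `COc1ccc(OC)c(/C=C/C(=O)Nc2cc3c(Nc4ccc(F)c(Cl)c4)ncnc3cc2O[C@H]2CCOC2)c1`: 7300 nM
- compound 3 `O=C(/C=C/c1cc(Br)c(O)c(Br)c1)Nc1cc2c(Nc3ccc(F)c(Cl)c3)ncnc2cc1O[C@H]1CCOC1`: 28800 nM

Compound 1 has no single number: it is recorded only as "not active" (no number reported), so it cannot be placed exactly against the other two compounds. The next compound, compound 4 `COc1cc2ncnc(Nc3ccc(F)c(Cl)c3)c2cc1NC(=O)/C=C/c1cc(OC)c(OC)c(OC)c1`, keeps the core of compound 1 and changes only the aryl group: 3,4,5-trimethoxyphenyl in place of 4-methoxyphenyl on a double-bonded chain carbon bound to a double-bonded chain carbon. Compound 1 has no number. For the measured compounds named here, no step from it can be calculated. The nearest evidence is a replacement at the same place on the chain, a 3.9-fold higher number from compound 2 to compound 3 (0.60 log units; beyond the scatter). That step is modest, but compounds 2 and 3 also differ from compound 1 elsewhere, so it is only a loose guide. A step of similar modest size is therefore expected, and its direction can only be towards stronger inhibition, since compound 1 gave no number. Compound 4 may still return no number in this assay. For compound 4 the estimated value is 20000 nM, with an expected range of 6000 nM to 60000 nM.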

Compound 4, half-maximal inhibitory concentration: "not active" (no number reported)
No number was reported for compound 4; the estimate stays without a comparison.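

Compound 1 and compound 4 both lack a number in this assay, so no step can be read between them. The compounds shown leave open whether 3,4,5-trimethoxyphenyl in place of 4-methoxyphenyl changes cytotoxicity at all. No measured evidence bears on this result.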